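This account rests on a few compounds, and the source may have more. Where it says the series, first, only, none or still open, it means among the compounds named here.

Compound 1 `Cc1ccc2[nH]c(C(=O)N[C@H]3CN(S(=O)(=O)c4ccccc4)C[C@@H]3C(=O)NCCN(C)C)cc2c1` gives 16 uL/min in an ADME assay on cells (Hepatocyte, Rattus norvegicus) for metabolic stability; on this read-out lower numbers stand for slow clearance and higher numbers for fast clearance.
Compound 2 `Cc1ccc2[nH]c(C(=O)N[C@H]3CN(S(=O)(=O)c4cccnc4)C[C@@H]3C(=O)NCCN(C)C)cc2c1` gives 8 uL/min in this assay.
Compound 3 `Cc1ccc2[nH]c(C(=O)N[C@H]3CN(S(=O)(=O)c4ccnnc4)C[C@@H]3C(=O)NCCN(C)C)cc2c1` gives 2 uL/min in this assay.

Among these three, compound 3 stands at the lowest number: compound 2 is its nearest neighbour, and compound 1 is the furthest. Compound 4 `Cc1ccc2[nH]c(C(=O)N[C@H]3CN(S(=O)(=O)c4cnccn4)C[C@@H]3C(=O)NCCN(C)C)cc2c1` is the next compound to be measured in this assay. It differs from compound 3 in one place: pyrazin-2-yl in place of pyridazin-4-yl on a sulfonyl sulfur. The measured steps that bear on this change are those around the same sulfonyl sulfur: a 2.0-fold lower number from compound 1 to compound 2 (0.30 log units; within the scatter), an 8.0-fold lower number from compound 1 to compound 3 (0.90 log units; beyond the scatter) and a 4.0-fold lower number from compound 2 to compound 3 (0.60 log units; beyond the scatter). Among the compounds with values here, none of them swaps one six-membered aromatic ring with two hetero atoms for another, so no measured step matches the change directly. Since the ring that enters carries the same count of hetero atoms as the ring that leaves, a step no larger than the scatter is expected from compound 3 to compound 4, namely a 1.5-fold higher number from compound 3 to compound 4 (0.18 log units; within the scatter). Compound 4 is therefore estimated at 3 uL/min, with a range from 1 uL/min to 8 uL/min.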

Compound 4, intrinsic clearance in a liver preparation (reported as CLH), per the amount of preparation that the assay uses: 12 uL/min
Estimate against measurement, compound 4: 4.0-fold (0.60 log units) below; measured number above the stated range.
By their numbers in this assay, from the lowest: compound 3; then compounds 2, 4 and 1 (each within the scatter of the next).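

In this assay the count of hetero atoms on the sulfonyl sulfur does not settle the number: pyrazin-2-yl and pyridazin-4-yl match in every count, yet the swap gives a 6.0-fold higher number from compound 3 to compound 4 (0.78 log units; beyond the scatter) and so separates two rings that differ only in how their atoms are joined. Compound 4 also lies within the scatter of the compounds with fewer ring hetero atoms, with a 1.5-fold higher number from compound 2 to compound 4 (0.18 log units; within the scatter) and with a 1.3-fold lower number from compound 1 to compound 4 (0.12 log units; within the scatter) as well, so the low number of compound 3 belongs to the pyridazin-4-yl ring and not to every ring with two hetero atoms. No measurement on hand accounts for this gap.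

On these data alone, whether a pyrimidin-5-yl ring on the same sulfur would fall with pyridazin-4-yl or with pyrazin-2-yl stays open. So does whether the gap between these two rings holds on any other core.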